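This account rests on a few compounds, and the source may have more. Where it says the series, first, only, none or still open, it means among the compounds named here.

In a functional assay on A549 cells (Homo sapiens) for antiproliferative activity, read by sulforhodamine B assay, with a stated time of 72 h (on this read-out higher numbers stand for weaker inhibition and lower numbers for stronger inhibition), the measured compounds give these values:
- Compound 1 `CCCCS(=O)(=O)Nc1cc(-c2ccc3ncnc(NCCN(C)C)c3c2)cnc1OC` gives 1320 nM
- Compound 2 `CCCCS(=O)(=O)Nc1cc(-c2ccc3ncnc(NCc4ccncc4)c3c2)cnc1OC` gives 9420 nM
- Compound 3 `COc1ncc(-c2ccc3ncnc(NCCCN(C)C)c3c2)cc1NS(=O)(=O)c1ccc(F)cc1F` gives 2780 nM

Compound 3 at 2780 nM holds the second highest of the three numbers, above compound 1 and below compound 2. Compound 4 `CCCCS(=O)(=O)Nc1cc(-c2ccc3ncnc(NCCCN(C)C)c3c2)cnc1OC` is the next to be read. The change is butyl in place of 2,4-difluorophenyl on a sulfonyl sulfur and it puts butyl in place of 2,4-difluorophenyl on a sulfonyl sulfur.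

Among the measured compounds shown here, no measured step covers this place. The only one available, a 7.1-fold higher number from compound 1 to compound 2 (0.85 log units; beyond the scatter) at another place, is a guide to size alone. Compound 1 already carries butyl on the sulfonyl sulfur and shows 1320 nM in this assay but differs from compound 4 in its chain. A small shift toward a lower number is therefore expected, one that stays within the scatter. The expected change is a 1.5-fold lower number from compound 3 to compound 4 (0.19 log units; within the scatter) on this reasoning. The estimated value for compound 4 is 1800 nM within an expected range of 650 nM to 4500 nM until it is measured.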

Compound 4, half-maximal inhibitory concentration: 3520 nM
Compound 4: middle estimate off by 2.0-fold (0.29 log units), on the low side, and the stated range covers the measured number.
By their numbers in this assay, from the lowest: compound 1; then compounds 3 and 4 (each within the scatter of the next); then compound 2.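

In this assay, the step at the sulfonyl sulfur is a 1.3-fold higher number from compound 3 to compound 4 (0.10 log units; within the scatter), so butyl and 2,4-difluorophenyl are not told apart on this read-out, at least in this one pair. The amine side of the molecule does separate compounds, with a 2.7-fold higher number from compound 1 to compound 4 (0.43 log units; beyond the scatter) for (dimethylamino)methyl in place of dimethylamino and a 2.7-fold lower number from compound 2 to compound 4 (0.43 log units; beyond the scatter) for 2-(dimethylamino)ethyl in place of pyridin-4-yl. No measurement is at hand to explain any of these steps.

Among the compounds shown here, only this one pair compares the two sulfonyl groups, so it remains open whether they would also match on the side chain of compound 1 or compound 2. Also open, from the compounds shown here alone, is how a methyl or an unsubstituted phenyl on the sulfonyl sulfur, or a morpholine at the end of the side chain, would read.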